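The compounds below may be only part of what the source reports. "The series", "measured", "known", "first", "only" and "open" are said of these compounds alone.

Compound 3, `Nc1cc(N)c2nc(-c3ccccc3)c(NCc3ccc(Cl)c(Cl)c3)nc2c1`, belongs to a small set of compounds tested in a functional assay on SNB-19 cells (Homo sapiens) for inhibition, read by sulforhodamine B assay, with a stated time of 48 h; on this read-out lower numbers stand for higher toxicity in this test and higher numbers for lower toxicity in this test. In this assay compound 3 gives < 100000 nM, which is a limit of the assay and not a measured number. Its two companions sit at the same point. Compound 1, `Nc1cc(N)c2nc(-c3ccccc3)c(Oc3ccc(Cl)c(Cl)c3)nc2c1`, gives < 100000 nM, again a limit. Compound 2, `CCOC(=O)[C@H](CCC(=O)O)NC(=O)c1ccc(CNc2nc3cc(N)cc(N)c3nc2-c2ccccc2)cc1`, gives < 100000 nM, once more a limit. Because of the limit of < 100000 nM in this assay, at which 3 of the 3 values shown sit, compound 3 cannot be placed above or below either of the others on the numbers available; all three share one unresolved position at the edge of what the assay reports.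

Compound 4, `COc1ccc(CNc2nc3cc(N)cc(N)c3nc2-c2ccccc2)cc1OC`, has not yet been measured in this assay. It differs from compound 3 in one place: 3,4-dimethoxyphenyl in place of 3,4-dichlorophenyl on a saturated chain carbon bound to a nitrogen on an aromatic ring. Within the data shown here, the account has no measured step between any two of the compounds, so there is no ruler for this change. The three limits point the same way, and the expectation is that compound 4 lands at the same limit, with no step beyond the scatter, so that a step that the limit leaves unreadable from compound 3 to compound 4 is expected to be an estimated step of no real size. The expected value for compound 4 in this assay is 70000 nM, with a range from 15000 nM to 100000 nM.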

Compound 4, concentration lethal to 50% of the cells: < 100000 nM
Compound 4: only a limit was reported (the forecaster's own chance of this, stated with the estimate: 75%); the middle value lies beyond the limit too.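

No step can be read from compound 3 to compound 4, because both values are limits and not numbers: the limit of < 100000 nM in this assay, at which 4 of the 4 values shown sit. The compounds shown leave open where any of the four truly stands on this read-out, and so whether 3,4-dimethoxyphenyl in place of 3,4-dichlorophenyl makes any difference.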